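Amine swap across two cores: working notes

The source may hold more compounds than are shown below. What is called first, only, known or untested is meant among the compounds shown, and "the series" means these compounds.

Measured so far, in a functional assay on U-937 cells (Homo sapiens) for antiproliferative activity, read by CCK-8 assay, with a stated time of 24 h; on this read-out higher numbers stand for weaker inhibition and lower numbers for stronger inhibition:
compound 1 `CCN(CC)Cc1ccc(NC(=O)NN=C(c2ccccn2)c2ccccn2)cc1` — compound 1 gives > 40000 nM, a limit of the assay.
compound 2 `CC1CCN(Cc2ccc(NC(=O)NN=C(c3ccccn3)c3ccccn3)cc2)CC1` — compound 2 gives > 40000 nM, a limit of the assay.
compound 3 `CCN(CC)Cc1ccc(NC(=O)NN=C(c2ccccc2)c2ccccc2)cc1` — compound 3 gives > 25000 nM, a limit of the assay.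

Two of the three values sit at the limit of > 40000 nM in this assay, at which 2 of the 3 values shown sit, and one at the limit of > 25000 nM in this assay, at which 1 of the 3 values shown sits. The change from compound 1 to compound 2 is 4-methylpiperidin-1-yl in place of diethylamino on a saturated chain carbon bound to an aromatic carbon; it made a step that the two limits leave unreadable from compound 1 to compound 2. Compound 4 `CC1CCN(Cc2ccc(NC(=O)NN=C(c3ccccc3)c3ccccc3)cc2)CC1` is not yet measured; it differs from compound 3 by 4-methylpiperidin-1-yl in place of diethylamino on a saturated chain carbon bound to an aromatic carbon, the same change at the same place. The difference between the two cores is not broken down here. Because compound 1 and compound 2 both sit at the limit of > 40000 nM in this assay, at which 2 of the 3 values shown sit, with the step between them unreadable, the step from compound 3 to compound 4 in this assay is expected to be a step that the limit leaves unreadable from compound 3 to compound 4, most likely again reported only as a limit. Compound 4 is expected to give 50000 nM, estimated between 20000 nM and 150000 nM.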

Compound 4, half-maximal inhibitory concentration: > 25000 nM
Compound 4 gave a limit, no number; the forecaster's own chance of this, stated with the estimate: 85%; the middle value lies beyond the limit too.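

Compound 4 gives > 25000 nM as a limit and not a number, and the step from compound 3 to compound 4 cannot be read. The compounds shown leave open, in this assay and on either core, what size the amine change has.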